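This account rests on a few compounds, and the source may have more. Where it says the series, first, only, none or still open, it means among the compounds named here.

Of the compounds shown here, three of a shared core have been tested in a functional assay on MDA-MB-231 cells (Homo sapiens) for antiproliferative activity, read by MTT assay, with a stated time of 24 h; a higher number here means a weaker inhibitor, a lower number a stronger inhibitor. Compound 1 `COc1cc(-c2cc(C(=O)/C=C/c3ccc(Cl)cc3)nc3cc(-c4ccccc4)nn23)cc(OC)c1OC` gives 21600 nM. Compound 2 `COc1cc(-c2cc(C(=O)/C=C/c3ccccc3)nc3cc(-c4ccccc4)nn23)cc(OC)c1OC` gives 19200 nM. The change from compound 2 to compound 1 is chloro in place of hydrogen on an aromatic carbon and it made a 1.1-fold higher number from compound 2 to compound 1 (0.05 log units; within the scatter). Compound 3 `COc1ccc(-c2cc(/C=C/C(=O)c3ccccc3)nc3cc(-c4ccccc4)nn23)cc1OC` gives 11800 nM; its values and those of compound 2 and compound 1 lie within the scatter of one another, so no order among the three can be claimed. The difference between the core of compound 3 and that of compound 2 is not broken down here.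

Compound 4 `COc1ccc(-c2cc(/C=C/C(=O)c3ccc(Cl)cc3)nc3cc(-c4ccccc4)nn23)cc1OC` has not yet been measured in this assay. It differs from compound 3 by chloro in place of hydrogen on an aromatic carbon. This is the same change as that from compound 2 to compound 1, at a place described in identical words. The step from compound 3 to compound 4 is expected to be a 1.1-fold higher number from compound 3 to compound 4 (0.04 log units; within the scatter) because the same change earlier gave a 1.1-fold higher number from compound 2 to compound 1 (0.05 log units; within the scatter). For compound 4 the expected value in this assay is 13000 nM, estimated to fall between 6000 nM and 27000 nM.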

Compound 4, half-maximal inhibitory concentration: 17100 nM
For compound 4 the middle estimate is 1.3-fold (0.12 log units) below the measured one; measured number inside the range.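

In this assay putting chloro in place of hydrogen on an aromatic carbon gave a 1.4-fold higher number from compound 3 to compound 4 (0.16 log units; within the scatter) and so stays within the scatter on this core as well. Set beside the earlier step, the two results cannot be told apart: the same change on two cores in this assay, a 1.1-fold higher number (0.05 log units; within the scatter) from compound 2 to compound 1 and a 1.4-fold higher number (0.16 log units; within the scatter) from compound 3 to compound 4, 1.3-fold (0.11 log units) apart, within the scatter of two such steps. Within the data shown here, this shows that the change from phenyl to 4-chlorophenyl carried over between these two cores with no step that stands clear of the scatter, but it does not show that chloro has a real effect in either core, and two pairs of compounds cannot show that the same would hold on a further core.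

The compounds shown carry only hydrogen or chloro at this place on the ring, so it remains open whether an amine or a carboxylic acid there would give a step beyond the scatter. Also open, from the compounds shown here alone, is how chloro would behave elsewhere on that ring.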